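The source may report more compounds than this note shows. Statements on the series, on what has been measured and on what is new or still open speak of the compounds shown alone.

In a functional assay on the whole organism (strain Kunming) with Mus musculus as the target, in the formalin test, with a stated time of 0.5 h (on this read-out higher numbers stand for an effect only at larger amounts of compound and lower numbers for an effect already at smaller amounts), compound 2, `COc1cc(OC)c(OC)cc1/C=C/COC(=O)/C=C/c1ccc(Br)cc1`, gives 105 mg/kg. Compound 1, `COc1cc(OC)c(OC)cc1/C=C/COC(=O)/C=C/c1cc(OC)c(OC)c(OC)c1OC`, gives 42.2 mg/kg, a smaller number that lies beyond the scatter from that of compound 2. Compound 3, `COc1cc(OC)c(OC)cc1/C=C/COC(=O)/C=C/c1ccc(OC)c(OC)c1OC`, gives 78.4 mg/kg, which lies within the scatter of compound 2. Compound 4, `COc1ccc(/C=C/C(=O)OC/C=C/c2cc(OC)c(OC)cc2OC)cc1`, has not yet been measured. It departs from compound 2 by one change, methoxy in place of bromo on an aromatic carbon, para to a large group: methoxy in place of bromo on an aromatic carbon. Going by the values given here, no measured step makes this exchange. Among the compounds with values here, the only measured step between closely matched compounds is a different change, hydrogen in place of methoxy on an aromatic carbon, and it gives a 1.9-fold higher number from compound 1 to compound 3 (0.27 log units; within the scatter). That step offers weak guidance, and it gives no reason to expect a large move. In this assay, the expected result is a 1.2-fold lower number from compound 2 to compound 4 (0.09 log units; within the scatter), a step that would not go beyond the scatter. For compound 4, the estimated value is 85 mg/kg, with an expected range from 40 mg/kg to 170 mg/kg.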

Compound 4, dose for half-maximal effect: 122 mg/kg
Compound 4: middle estimate off by 1.4-fold (0.16 log units), on the low side; measured number inside the range.
By their numbers in this assay, from the lowest: compounds 1, 3, 2 and 4 (each within the scatter of the next, the first and the last beyond it).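

In this assay, methoxy in place of bromo on an aromatic carbon, para to a large group, gives a 1.2-fold higher number from compound 2 to compound 4 (0.07 log units; within the scatter) and so stays within the scatter: at this read-out, 4-bromophenyl and 4-methoxyphenyl are not told apart. The earlier compounds shown here offered only a different exchange, hydrogen in place of methoxy, as a 1.9-fold higher number from compound 1 to compound 3 (0.27 log units; within the scatter) shows, and so said nothing about this position or about bromo against methoxy. No measurement at hand speaks to why the two groups read alike.

From the compounds shown here alone, whether an amine or a carboxylic acid at this position would also stay within the scatter of compound 2 remains open. So does whether the exchange of bromo for methoxy would read the same on a ring that carries further methoxy groups.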